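The source may report more compounds than this note shows. Statements on the series, on what has been measured and on what is new or still open speak of the compounds shown alone.

In an assay on isolated protein for displacement of a labelled ligand from metabotropic glutamate receptor 5 (Homo sapiens), with a stated time of 60 min, tested at 1 uM (a higher number here means more inhibition at the concentration tested (going by the name of the read-out), a lower number less inhibition), compound 1 `Cc1ccc(S(=O)(=O)c2cnc3cc(Cl)ccc3c2N2CCC(C)CC2)cc1F` gives 85%, the highest number among the three measured compounds. Compound 2 `Cc1ccc2ncc(S(=O)(=O)c3cc(Cl)cc(Cl)c3)c(N3CCC(C)CC3)c2c1` gives 75%, a number that lies within the scatter of the value of compound 1, so the two cannot be ranked against each other. Compound 3 `CN1CCN(c2c(S(=O)(=O)c3ccccc3)cnc3ccccc23)CC1` gives 7.7%, which falls far below compound 1, well beyond the scatter. Compound 4 `Cc1ccc(S(=O)(=O)c2cnc3cc(Cl)ccc3c2N2CCC(C)CC2)cc1Cl` has not yet been measured in this assay. It differs from compound 1 in one place: chloro in place of fluoro on an aromatic carbon. No measured pair shows this exchange, so its effect has no precedent among these compounds. Compound 4 is expected to show a number 1 percentage points lower from compound 1 to compound 4 (within the scatter), a step in no direction beyond the scatter. Compound 4 is thus estimated at 84%, with a range from 70% to 95%.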

Compound 4, a percentage reported as inhibition, at one concentration (the size of the read-out at that concentration, not a potency): 89%
The estimate for compound 4 lay 5 percentage points below the measured number; the range from low to high includes it.
By their numbers in this assay, from the lowest: compound 3; then compounds 2, 1 and 4 (each within the scatter of the next, the first and the last beyond it).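

Chloro in place of fluoro on the aromatic carbon ortho to the methyl group gives, in this assay, a number 4 percentage points higher from compound 1 to compound 4 (within the scatter) and so leaves the read-out where it was. For the compounds shown here, no earlier pair covered this place, and the two halogens cannot be told apart here at one concentration, which is not a potency. The data offer no explanation for this result.

On these data alone, whether a methoxy or a trifluoromethyl group would be held as well at this place remains open. So does whether the exchange would read the same with a morpholine in place of the 4-methylpiperidine.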